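The compounds below may be only part of what the source reports. "The series", "measured", "known", "first", "only" and "open" are said of these compounds alone.

Of the compounds shown here, three built on a shared core have been tested in an assay on membranes from brain for displacement of a labelled ligand from Sigma non-opioid intracellular receptor 1 (Cavia porcellus), read by scintillation counting, with a stated time of 120 min (on this read-out higher numbers stand for weaker inhibition and lower numbers for stronger inhibition), and every one of them has returned only a limit. Compound 1 `COc1cc2c(cc1OC)CN(CCC(=O)c1c(C)c(OC)c(OC)c(OC)c1O)CC2` gives > 1000 nM in this assay, which is a limit of the assay rather than a measured number. Compound 2 `COc1ccc(C(O)CCN2CCc3cc(OC)c(OC)cc3C2)c(C)c1` likewise gives > 1000 nM, again a limit. Compound 3 `COc1ccc(C(O)CCCCN2CCc3cc(OC)c(OC)cc3C2)c(C)c1` gives > 1000 nM, which is also a limit. Compound 3 therefore stands nowhere distinct among the numbers shown: all three measured compounds sit at the limit of > 1000 nM in this assay, at which 3 of the 3 values shown sit, and no step between any two of them can be read, as each value is only a limit.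

Compound 4 `COc1ccc(C(O)CCCCN2CCc3cc(OC)c(OC)cc3C2)c(OC)c1` differs from compound 3 in a single place: methoxy in place of methyl on an aromatic carbon. Going by the values given here, with no measured step to lean on, and with compound 3 resting at a limit, the expectation is that this exchange moves the value little if at all, and that the most likely outcome for compound 4 is once more a limit. Compound 4 is expected to give about 3000 nM, with a range from 1000 nM to 15000 nM. The step expected from compound 3 to compound 4 is thus a step that the limit leaves unreadable from compound 3 to compound 4, which is no change beyond the usual scatter of repeated measurements.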

Compound 4, inhibition constant: > 1000 nM
Compound 4 ended at the assay's limit; the forecaster's own chance of this, stated with the estimate: 85%; the middle value lies beyond the limit too.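

Compound 3 and compound 4 both return only a limit in this assay, so no step from one to the other can be read, and the effect of methoxy in place of methyl stays unsized: the limit of > 1000 nM in this assay, at which 4 of the 4 values shown sit.

The compounds shown leave open how strong the inhibition of any of them really is, and which change to the shared core would bring a measured number in this assay.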